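The source may report more compounds than this note shows. Statements on the series, on what has been measured and on what is new or still open speak of the compounds shown alone.

For the measured compounds named here, in a functional assay (aorta) with Rattus norvegicus as the target (on this read-out higher numbers stand for an effect only at larger amounts of compound and lower numbers for an effect already at smaller amounts), compound 2 `O=c1ccccn1[C@@H]1c2cc([N+](=O)[O-])ccc2OC(CF)(CF)[C@H]1O` gives 28.8 nM, the higher of the two numbers measured so far. Compound 1 `O=C1CCCCN1[C@@H]1c2cc(C(F)(F)C(F)(F)F)ccc2OC(CF)(CF)[C@H]1O` gives 3.89 nM, and the gap between the two lies beyond the usual scatter. Compound 3 `O=c1ccccn1[C@@H]1c2cc(C(F)(F)C(F)(F)F)ccc2OC(CF)(CF)[C@H]1O` comes from compound 2 through a single change, 1,1,2,2,2-pentafluoroethyl in place of nitro on an aromatic carbon. The site is on a six-membered aromatic ring of carbon only, part of a fused system of two rings.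

Going by the values given here, no pair of measured compounds differs in one place only, so the size of this change has not been seen on its own. The expectation rests on compound 1, which carries the same 1,1,2,2,2-pentafluoroethyl and gives 3.89 nM. A single compound offers thin support, so the estimate stays wide. In this assay, a step towards a lower number, probably beyond the scatter, is expected. The estimated change is a 4.1-fold lower number from compound 2 to compound 3 (0.61 log units; beyond the scatter). For compound 3 the expected value is 7 nM, with an estimated range from 2 nM to 25 nM.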

Compound 3, half-maximal effective concentration: 12 nM
Estimate against measurement, compound 3: 1.7-fold (0.23 log units) below, and the stated range covers the measured number.
By their numbers in this assay, from the lowest: compound 1; then compound 3; then compound 2.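

With the ring group on the saturated ring carbon held constant, this assay now shows the effect of 1,1,2,2,2-pentafluoroethyl in place of nitro on the aromatic carbon on its own: the change gives a 2.4-fold lower number from compound 2 to compound 3 (0.38 log units; beyond the scatter) and so moves the number modestly but beyond the scatter. The aromatic carbon is therefore a position at which this exchange registers in the read-out, although this rests on one pair of compounds. With 1,1,2,2,2-pentafluoroethyl held constant, a second place also proves to matter, since exchanging the non-aromatic six-membered ring for the aromatic six-membered ring on the saturated ring carbon gives a 3.1-fold higher number from compound 1 to compound 3 (0.49 log units; beyond the scatter) and runs in the direction of a higher number, opposite to the step on the aromatic carbon.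

On these data alone, how trifluoromethyl, a nitrile or a simple amine would compare on the aromatic carbon remains open, as does how nitro would behave with the non-aromatic ring on the saturated ring carbon. As far as these compounds go, no measurement of any other property accompanies these numbers, so the basis of both steps also remains open.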